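The source may hold more compounds than are shown below. What is called first, only, known or untested is meant among the compounds shown, and "the series" means these compounds.

Measured so far:
compound 1, `CC1=CC[C@H](C(C)(C)NC(=S)N/N=C/c2ccc(F)cc2)CC1` — > 100000 nM
compound 2, `CC1=CC[C@H](C(C)(C)NC(=S)N/N=C/c2ccc(Cl)cc2)CC1` — > 100000 nM

In an ADME assay on Vero cells (Chlorocebus sabaeus) for inhibition, read by sulforhodamine B assay, with a stated time of 48 h (a lower number here means a stronger inhibitor of growth, a higher number a weaker inhibitor of growth), compound 1 gives > 100000 nM, which is a limit of the assay and not a number. In this assay compound 2 likewise gives > 100000 nM, again a limit. Going by the values given here, compound 2 therefore stands only at a limit, and the one further value is a limit as well, so the step that the two limits leave unreadable from compound 1 to compound 2 cannot be read in either size or direction; both values sit at the limit of > 100000 nM in this assay, at which 2 of the 2 values shown sit.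

Compound 3, `CC1=CC[C@H](C(C)(C)NC(=S)N/N=C/c2ccc[nH]2)CC1`, differs from compound 2 by 1H-pyrrol-2-yl in place of 4-chlorophenyl on a carbon with a double bond to nitrogen. Among the compounds with values here, no measured step bears directly on an exchange of this kind: the only step in hand is the unreadable one from compound 1 to compound 2, and it involves a halogen swap on the same ring rather than a change of ring. With both measured compounds at the limit, there is no basis for expecting compound 3 to move into the readable range. The expected step of a number no higher from compound 2 to compound 3 (the limit leaves the size open) is therefore none beyond the scatter, and compound 3 is expected near the limit, estimated at 100000 nM with a range from 30000 nM to 300000 nM; the most likely outcome is that only a limit is reported.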

Compound 3, concentration for total growth inhibition: > 100000 nM
Compound 3 ended at the assay's limit (the forecaster's own chance of this, stated with the estimate: 80%); the middle value lies on the limit itself.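

In this assay compound 3 gives > 100000 nM, a limit of the assay and not a number. The steps from compound 1 and compound 2 to compound 3 therefore cannot be read: the limit of > 100000 nM in this assay, at which 3 of the 3 values shown sit. The compounds shown leave open whether any change to the shared core gives a readable value in this assay.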